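This account rests on a few compounds, and the source may have more. Where it says the series, first, only, none or still open, it means among the compounds named here.

The measured compounds:

Compound 1, `O=C(Nc1ccc(Cl)c(-c2nnc3c(Cl)cccn23)c1)c1ccc(C(F)(F)F)cc1Cl`, in a functional assay on AN3-CA cells (Homo sapiens) for antiproliferative activity, read by MTT assay, with a stated time of 72 h (on this read-out lower numbers stand for stronger inhibition and higher numbers for weaker inhibition), gives only a limit of the assay, > 100000 nM.
Compound 2, `O=C(Nc1ccc(Cl)c(-c2nnc3c(Cl)cccn23)c1)c1ccc(F)cc1Cl`, in this assay gives only a limit of the assay, > 100000 nM.
Compound 3, `O=C(Nc1ccc(Cl)c(-c2nnc3c(Cl)cccn23)c1)c1ccccn1`, in this assay gives only a limit of the assay, > 100000 nM.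

Compound 3 therefore stands at the limit, and no number separates it from the two other measured compounds, since all three sit at the same limit (the limit of > 100000 nM in this assay, at which 3 of the 3 values shown sit). The two measured steps give no readable size: a step that the two limits leave unreadable from compound 1 to compound 2, and a step that the two limits leave unreadable from compound 2 to compound 3. The second of these is the one that bears most directly on the next change, as it also exchanges the whole aryl group on the carbonyl carbon, yet it leaves both ends at the limit.

Compound 4, `Cc1nc(C(=O)Nc2ccc(Cl)c(-c3nnc4c(Cl)cccn34)c2)cs1`, differs from compound 3 by 2-methyl-1,3-thiazol-4-yl in place of pyridin-2-yl on a carbonyl carbon. With no readable step among the measured compounds, there is no basis for expecting a step beyond the scatter in this assay in either direction. Compound 4 is accordingly expected to give about 100000 nM, within a range from 30000 nM to 300000 nM, most probably reported again only as a limit. The expected step is a number no higher from compound 3 to compound 4 (the limit leaves the size open).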

Compound 4, half-maximal inhibitory concentration: > 100000 nM
Compound 4 gave a limit, no number; the forecaster's own chance of this, stated with the estimate: 85%; the middle value sits exactly at the limit.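

In this assay compound 4 gives > 100000 nM, which is a limit of the assay and not a number. No step to compound 4 can be read from compound 2 or compound 3, since each pair has a limit at both ends: the limit of > 100000 nM in this assay, at which 4 of the 4 values shown sit.

The compounds shown leave open whether the groups on the carbonyl carbon differ at all in this assay.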